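Furan-2-yl in place of phenyl on the carbonyl carbon

The source may hold more compounds than are shown below. What is called first, only, known or untested is meant among the compounds shown, and "the series" means these compounds.

In an ADME assay on RAW264.7 cells (Mus musculus) for cytotoxicity, read by MTT assay (a higher number here means a weaker inhibitor, a lower number a stronger inhibitor), compound 1 `CN(C)c1ccc(/C=C/C=C/C(=O)c2ccccc2)cc1` gives > 100000 nM, which is a limit and not a number. Compound 2 `COc1ccc(C(=O)/C=C/C=C/c2ccc(N(C)C)cc2)cc1` gives > 100000 nM, also a limit. So the one measured step, a step that the two limits leave unreadable from compound 1 to compound 2, has no readable size, and the series so far shows only (the limit of > 100000 nM in this assay, at which 2 of the 2 values shown sit). That step is a methoxy change and does not touch the carbonyl carbon.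

Compound 3 `CN(C)c1ccc(/C=C/C=C/C(=O)c2ccco2)cc1` differs from compound 1 by furan-2-yl in place of phenyl on a carbonyl carbon. Within the data shown here, no measured step covers this change, so the expectation rests on the limit shared by the two measured compounds, (the limit of > 100000 nM in this assay, at which 2 of the 2 values shown sit). No step beyond the scatter is expected in this assay, and a further limit is the likeliest report. For compound 3 the estimated value is 100000 nM, with an expected range of 40000 nM to 200000 nM. This estimate corresponds to an expected a number no higher from compound 1 to compound 3 (the limit leaves the size open).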

Compound 3, half-maximal inhibitory concentration: > 100000 nM
Compound 3: a limit, no number (the forecaster's own chance of this, stated with the estimate: 70%); the middle value lies on the limit itself.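

No size can be read for the step between compound 1 and compound 3 in this assay, as each gives only a limit: the limit of > 100000 nM in this assay, at which 3 of the 3 values shown sit.

The compounds shown leave open how large the furan-2-yl step is and whether any change to the shared core gives a number in this assay.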